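A few compounds are considered here, and "the series" means these few. Any claim that something is new, unique, unknown or untested is made for them only; others in the source may bear on it.

Working notes on the series. Of the compounds shown here, two have been measured so far: compound 1 `CCOC(=O)[C@@H]1CC(=O)c2sccc2[C@H]1c1ccc(OC)cc1` and compound 2 `CCOC(=O)[C@@H]1CC(=O)c2sccc2[C@H]1c1ccccc1OC`, which share one core and differ only in the substitution of the aryl group. In a physicochemical assay, read by spectrophotometry, with a stated time of 20 min, tested at 80 ug/mL (a lower number here means a weaker effect, a higher number a stronger effect of the compound at the concentration tested), compound 1 gives 23.9%. In this assay compound 2 gives 19.7%. The two numbers lie within the usual scatter of each other, so compound 2 cannot be set apart from compound 1 on these data; both read as modest effects at the concentration tested.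

Compound 3 `CCOC(=O)[C@@H]1CC(=O)c2sccc2[C@H]1c1ccc(OC)cc1OC` is the next member, not yet measured in this assay. It carries the change methoxy in place of hydrogen on an aromatic carbon relative to compound 2. Going by the values given here, no step between measured compounds of this kind is available, so there is no measured precedent for the size of this change. Among the compounds with values here, the only measured pair, compound 1 against compound 2, shows that swapping the position of a single methoxy leaves the numbers within the scatter, and a second methoxy is expected to behave similarly. The expected step of a number 2.3 percentage points higher from compound 2 to compound 3 (within the scatter) is therefore small, in no firm direction, and not beyond the scatter. For compound 3 the estimate in this assay is 22%, with a likely range from 10% to 35%.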

Compound 3, a percentage reported as activity, at one concentration (the size of the read-out at that concentration, not a potency): 18.6%
Compound 3: the middle estimate sits 3.4 percentage points above what was measured, within the range that was stated.
By their numbers in this assay, from the lowest: compounds 3, 2 and 1 (each within the scatter of the next).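

In this assay, the first measured case of methoxy in place of hydrogen on an aromatic carbon gives a number 1.1 percentage points lower from compound 2 to compound 3 (within the scatter) and, starting from the other compound with a single methoxy, the step reads a number 5.3 percentage points lower from compound 1 to compound 3 (within the scatter) in the same assay. A second methoxy on the aryl group therefore leaves the read-out within the scatter from either starting point, which the earlier pair could not show, since its two members differ only in where one methoxy sits. With three compounds now indistinguishable, this position tolerates the added methoxy without a measurable shift in the read-out, and no measurement at hand bears on the reason for this.

From the compounds shown here alone, whether a hydroxyl or an amine on the aryl group would give a step beyond the scatter remains open. So does what a carboxylic acid or a longer chain in place of the ethyl ester would do, that ester being common to all three compounds.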